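Benzylamino nucleosides in K562 proliferation: three limits so far

The compounds below may be only part of what the source reports. "The series", "measured", "known", "first", "only" and "open" are said of these compounds alone.

Measured compounds:
compound 1 `COc1cccc(CNc2ncnc3c2ncn3[C@@H]2O[C@H](CO)[C@@H](O)[C@H]2O)c1`: > 166000 nM
compound 2 `OC[C@H]1O[C@@H](n2cnc3c(NCc4cc(F)cc(F)c4)ncnc32)C(O)C1O`: > 166000 nM
compound 3 `COc1cc(CNc2ncnc3c2ncn3[C@@H]2O[C@H](CO)[C@@H](O)[C@H]2O)cc(OC)c1O`: > 166000 nM

In a functional assay on K562 cells (Homo sapiens) for antiproliferative activity, with a stated time of 72 h (on this read-out higher numbers stand for weaker inhibition and lower numbers for stronger inhibition), compound 1 gives > 166000 nM, which is a limit of the assay and not a number. Compound 2 gives > 166000 nM in this assay, again a limit. Compound 3 gives > 166000 nM in this assay, a limit as well. So far: the limit of > 166000 nM in this assay, at which 3 of the 3 values shown sit. Compound 1 therefore holds no place on a numerical scale; its result is a limit, as are the other two shown.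

Compound 4 `Cc1ccc(O)c(CNc2ncnc3c2ncn3[C@@H]2O[C@H](CO)[C@@H](O)[C@H]2O)c1` awaits measurement in this assay. It differs from compound 1 in one place: 2-hydroxy-5-methylphenyl in place of 3-methoxyphenyl on a saturated chain carbon bound to a nitrogen on an aromatic ring. Among the measured compounds shown here, no step between two measured compounds is available, so the size of this change in this assay is untested. With every shown value sitting at the limit, the step from compound 1 to compound 4 is expected to be none beyond the scatter, a number no higher from compound 1 to compound 4 (the limit leaves the size open). Compound 4 is expected to give 166000 nM, within 60000 nM to 500000 nM, most probably again reported as a limit.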

Compound 4, half-maximal inhibitory concentration: 16500 nM
Beside the measured number, compound 4's estimate is 10-fold (1.00 log units) above it; measured number below the stated range.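

In this assay, 2-hydroxy-5-methylphenyl in place of 3-methoxyphenyl, on a saturated chain carbon bound to a nitrogen on an aromatic ring, gives an at least 10-fold lower number from compound 1 to compound 4 (1.00 log units; beyond the scatter), so this position can move the read-out off the limit. The two compounds have the same atoms, joined differently, and the entering group counts 1 hydrogen-bond donor where the leaving group counts 0, so the step arises with no change in the number of heavy atoms. The true size of the step stays unknown because the starting value of compound 1 is a limit of the assay and not a number: the limit of > 166000 nM in this assay, at which 3 of the 4 values shown sit.

Among the compounds shown here, no single step separates the hydroxy from the methyl within 2-hydroxy-5-methylbenzyl. From the compounds shown here alone, how an amine in place of that hydroxy, or an ethyl in place of that methyl, would read remains open.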